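A few compounds are considered here, and "the series" means these few. Any claim that something is new, unique, unknown or untested is made for them only; others in the source may bear on it.

Among the compounds with values here, in a functional assay on A549/CDDP cells (Homo sapiens) for antiproliferative activity, read by MTT assay, with a stated time of 72 h (on this read-out lower numbers stand for stronger inhibition and higher numbers for weaker inhibition), three compounds sharing one core have numbers so far. Compound 1 `Cc1nc(C)c(/C=C/C(=O)/C=C/c2ccccc2O)nc1C` gives 3900 nM, compound 2 `Cc1nc(C)c(/C=C/C(=O)/C=C/c2ccc(O)cc2)nc1C` gives 4790 nM, and compound 3 `COc1cc(/C=C/C(=O)/C=C/c2nc(C)c(C)nc2C)ccc1O` gives 600 nM. Compound 2 therefore stands level with compound 1, within the scatter, and well above compound 3.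

Compound 4 `Cc1nc(C)c(/C=C/C(=O)/C=C/c2ccc(F)cc2)nc1C` differs from compound 2 in one place: fluoro in place of hydroxy on an aromatic carbon. In words, this is fluoro in place of hydroxy on an aromatic carbon, para to a large group.

Within the data shown here, two measured steps bear on this change, both only indirectly. Exchanging 2-hydroxyphenyl for 4-hydroxyphenyl gave a 1.2-fold higher number from compound 1 to compound 2 (0.09 log units; within the scatter), which is within the scatter. Putting methoxy in place of hydrogen on an aromatic carbon gave an 8.0-fold lower number from compound 2 to compound 3 (0.90 log units; beyond the scatter), a modest step beyond the scatter, but that change replaced no hydroxy. All three measured compounds carry a hydroxy, so the data do not show what replacing it does.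

With only the small step of a 1.2-fold higher number from compound 1 to compound 2 (0.09 log units; within the scatter) touching that group directly, no large shift is expected, though the uncertainty is wide. The expected step in this assay is a 1.3-fold lower number from compound 2 to compound 4 (0.10 log units; within the scatter). For compound 4 the estimate is 3800 nM, with an expected range from 1200 nM to 12000 nM.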

Compound 4, half-maximal inhibitory concentration: 7440 nM
Beside the measured number, compound 4's estimate is 2.0-fold (0.29 log units) below it, within the range that was stated.
By their numbers in this assay, from the lowest: compound 3; then compounds 1, 2 and 4 (each within the scatter of the next).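

Within the data shown here, compound 4 is the first compound here to carry no hydroxy, and in this assay fluoro in place of hydroxy on an aromatic carbon, para to a large group, gives a 1.6-fold higher number from compound 2 to compound 4 (0.19 log units; within the scatter), so at this place a hydroxy is not required for a number in the range of compound 2. The same holds against the other hydroxy compound: 4-fluorophenyl in place of 2-hydroxyphenyl gives a 1.9-fold higher number from compound 1 to compound 4 (0.28 log units; within the scatter), which means that neither exchange moves the number beyond the scatter, and the one step beyond it among these compounds remains the one to compound 3. Nothing available explains why the exchange of hydroxy for fluoro leaves the number within the scatter.

The compounds shown leave open what a larger or charged group would do at this place, such as an amine, a carboxylic acid or a longer chain ending in either. They also leave open whether methoxy in place of hydrogen on an aromatic carbon, the change behind an 8.0-fold lower number from compound 2 to compound 3 (0.90 log units; beyond the scatter), would give a step of similar size with fluoro standing where the hydroxy stands in compound 3.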